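Methyl for methoxy on the aryl of compound 2

The compounds below may be only part of what the source reports. "The series", "measured", "known", "first", "only" and "open" are said of these compounds alone.

Three analogues sharing one core have been measured in a functional assay on Huh-7 cells (Homo sapiens) for inhibition, read by sulforhodamine B assay, with a stated time of 72 h; a lower number here means a stronger inhibitor, a higher number a weaker inhibitor. Compound 1 `CC(c1ccc(-c2ccccc2)c(F)c1)c1nnc2n1N=C(c1ccc(Cl)cc1Cl)CS2` gives 3700 nM, compound 2 `COc1ccc(C2=Nn3c(nnc3C(C)c3ccc(-c4ccccc4)c(F)c3)SC2)cc1` gives 4300 nM, and compound 3 `CC(C)Cc1ccc(C(C)c2nnc3n2N=C(c2ccc(Cl)cc2Cl)CS3)cc1` gives 7500 nM. Compound 2 stands second highest of the three, and both neighbours lie within the scatter of it. Among the measured compounds shown here, the only single-point step known, a 1.2-fold higher number from compound 1 to compound 2 (0.07 log units; within the scatter), changed the aryl on the carbon double-bonded to nitrogen without effect beyond the scatter. Compound 4 `Cc1ccc(C2=Nn3c(nnc3C(C)c3ccc(-c4ccccc4)c(F)c3)SC2)cc1` differs from compound 2 by methyl in place of methoxy on an aromatic carbon. For the measured compounds named here, no measured step tests this exact change; the one step on that aryl was flat, so no step beyond the scatter is expected in this assay, a 1.0-fold higher number from compound 2 to compound 4 (0.02 log units; within the scatter). Compound 4 is estimated at 4500 nM, within 1800 nM to 11000 nM.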

Compound 4, half-maximal inhibitory concentration: 7200 nM
Estimate against measurement, compound 4: 1.6-fold (0.20 log units) below; low and high end bracket the measured number.
By their numbers in this assay, from the lowest: compounds 1, 2, 4 and 3 (each within the scatter of the next, the first and the last beyond it).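

In this assay, a 1.7-fold higher number from compound 2 to compound 4 (0.22 log units; within the scatter) comes with methyl in place of methoxy on the aromatic carbon, and a 1.9-fold higher number from compound 1 to compound 4 (0.29 log units; within the scatter) comes with 4-methylphenyl in place of 2,4-dichlorophenyl. Three aryl groups have now been read at this position, and every step among them stays within the scatter, so the assay has not separated them. Nothing measured here offers an explanation for these steps.

Still open, from the compounds shown here alone, is whether an amine or a carboxylic acid on this aryl would give a step beyond the scatter.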